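Removing the chloro from the benzoyl ester of compound 2

The source may report more compounds than this note shows. Statements on the series, on what has been measured and on what is new or still open speak of the compounds shown alone.

Of the compounds shown here, two have so far been measured in a functional assay (Homo sapiens) for inhibition, tested at 1 uM; a lower number here means a weaker effect, a higher number a stronger effect of the compound at the concentration tested. Compound 1 `CO/C(O)=C(/C=N/c1ccc(Oc2ccccc2OC(C)C)nc1)NC(=O)c1ccccc1` gives 73% in this assay. Compound 2 `Cc1c(Cc2c(Cl)cccc2Cl)c(=O)oc2cc(OCC(=O)OCC(=O)c3ccc(Cl)cc3)ccc12` gives 74% in this assay, the higher of the two numbers, although the gap to compound 1 lies within the scatter, so neither can be placed ahead of the other.

Compound 3 `Cc1c(Cc2c(Cl)cccc2Cl)c(=O)oc2cc(OCC(=O)OCC(=O)c3ccccc3)ccc12` has not yet been measured. It differs from compound 2 in one place: hydrogen in place of chloro on an aromatic carbon. Among the measured compounds shown here, no pair of measured compounds differs in a single place, so there is no measured step that shows what removing a chloro does here. The account therefore rests on compound 2 alone, whose inhibition of 74% is the only anchor. The step from compound 2 to compound 3 is expected to be a number 6 percentage points lower from compound 2 to compound 3 (within the scatter), a small loss that stays within the scatter. Compound 3 is estimated to give 68% in this assay, with a range from 45% to 85%.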

Compound 3, a percentage reported as inhibition, at one concentration (the size of the read-out at that concentration, not a potency): 60%
Compound 3: the middle estimate sits 8 percentage points above what was measured; measured number inside the range.
By their numbers in this assay, from the lowest: compound 3; then compounds 1 and 2 (each within the scatter of the next).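

In this assay, among the compounds shown here, the change from 4-chlorophenyl to phenyl gives a number 14 percentage points lower from compound 2 to compound 3 (beyond the scatter) and is the only single-place step available here, so it shows that the chloro on this aromatic carbon, para to a large group, contributes to the read-out. Inhibition does not vanish without it, since compound 3 still gives 60% at the concentration tested, so the rest of the molecule carries much of the effect. Nothing measured on these compounds explains why the chloro matters at this position.

The compounds shown leave open whether the gain is specific to chloro or would also appear with another group at this carbon, such as fluoro, bromo, methoxy or an amine. They also leave open whether the same change would have a similar effect on a different core, such as that of compound 1.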